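A few compounds are considered here, and "the series" means these few. Any claim that something is new, unique, unknown or untested is made for them only; others in the source may bear on it.

Compound 1 `CCN(CC)Cc1ccc2nc(NC(=O)N/N=C/c3cn(Cc4cccc(Cl)c4)c4ccccc34)sc2c1` gives 220 nM in a functional assay on NCI-H460 cells (Homo sapiens) for cytotoxicity, read by MTT assay, with a stated time of 72 h; a higher number here means a weaker inhibitor, a lower number a stronger inhibitor.
Compound 2 `CN(C)Cc1ccc2nc(NC(=O)N/N=C/c3cn(Cc4cccc(Cl)c4)c4ccccc34)sc2c1` gives 420 nM in this assay.
Compound 3 `CN(C)Cc1ccc2nc(NC(=O)N/N=C/c3cn(Cc4ccc(Cl)c(Cl)c4)c4ccccc34)sc2c1` gives 1360 nM in this assay.

All three share one core and differ only in small side groups. Compound 2 and compound 1 differ by diethylamino in place of dimethylamino on a saturated chain carbon bound to an aromatic carbon, and that change gave a 1.9-fold lower number from compound 2 to compound 1 (0.28 log units; within the scatter). Compound 3 differs from compound 2 by chloro in place of hydrogen on an aromatic carbon, which gave a 3.2-fold higher number from compound 2 to compound 3 (0.51 log units; beyond the scatter), so compound 3 carries the highest number of the three measured compounds.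

Compound 4 `CCN(CC)Cc1ccc2nc(NC(=O)N/N=C/c3cn(Cc4ccc(Cl)c(Cl)c4)c4ccccc34)sc2c1` has not yet been measured in this assay. It differs from compound 3 by diethylamino in place of dimethylamino on a saturated chain carbon bound to an aromatic carbon. The place is the same word for word as in the step from compound 2 to compound 1, so this is the same change, now made on the core that carries the second chloro group. Among the compounds with values here, only one earlier example of this change exists, so the expectation rests on it alone. Within the data shown here, compound 4 is expected to show a 1.8-fold lower number from compound 3 to compound 4 (0.26 log units; within the scatter) because a 1.9-fold lower number from compound 2 to compound 1 (0.28 log units; within the scatter) is the only measured guide for this change. Compound 4 is therefore estimated at about 750 nM, most likely between 350 nM and 1600 nM.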

Compound 4, half-maximal inhibitory concentration: 610 nM
Estimate against measurement, compound 4: 1.2-fold (0.09 log units) above, and the stated range covers the measured number.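

In this assay, putting diethylamino in place of dimethylamino on the core with the second chloro group gave a 2.2-fold lower number from compound 3 to compound 4 (0.35 log units; beyond the scatter), and this agrees with the same change on the core with one chloro group: the same change on two cores in this assay, a 1.9-fold lower number (0.28 log units; within the scatter) from compound 2 to compound 1 and a 2.2-fold lower number (0.35 log units; beyond the scatter) from compound 3 to compound 4, 1.2-fold (0.07 log units) apart, within the scatter of two such steps. Adding the chloro group to the diethylamino compound gave a 2.8-fold higher number from compound 1 to compound 4 (0.44 log units; beyond the scatter), and this change also carried over from one partner to the other: the same change on two cores in this assay, a 3.2-fold higher number (0.51 log units; beyond the scatter) from compound 2 to compound 3 and a 2.8-fold higher number (0.44 log units; beyond the scatter) from compound 1 to compound 4, 1.2-fold (0.07 log units) apart, within the scatter of two such steps. Within these four compounds, each change therefore shifted the number by a similar amount in both settings, but that rests on only two examples per change in a single assay, and it neither shows that the pattern extends to other cores nor explains why the numbers move.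

As far as these compounds go, it remains open whether a longer chain such as dipropylamino or a ring amine such as morpholine, placed on the same saturated chain carbon, would continue the shift seen with diethylamino. From the compounds shown here alone, it is also open whether a bromo or methoxy group in place of the added chloro would raise the number as chloro does.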